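This account rests on a few compounds, and the source may have more. Where it says the series, first, only, none or still open, it means among the compounds named here.

Two compounds of this series carry a measurement so far. Compound 1 `CC(=O)N1CCC(C(=O)Nc2sc3c(c2C(=O)NC2CC2)CCC(C)C3)CC1` gives 50% in an assay for displacement of a labelled ligand from DNA repair protein REV1 (Homo sapiens), read by fluorescence polarization, with a stated time of 1 h, tested at 1 uM; on this read-out lower numbers stand for less inhibition and higher numbers for more inhibition at the one concentration tested (going by the name of the read-out). Compound 2 `CCCC1CCc2c(sc(NC(=O)C3CCN(C(C)=O)CC3)c2C(N)=O)C1` gives in this assay the value 50%, level with compound 1 at the digits shown; the two readings fall within the scatter of each other, so no order between them can be drawn. Within the data shown here, no measured pair differs in a single place, and no step size is therefore known from the data.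

Compound 3 `CC(=O)N1CCC(C(=O)Nc2sc3c(c2C(N)=O)CCC(C)C3)CC1` remains to be measured. It differs from compound 2 by hydrogen in place of ethyl on a saturated chain carbon bound to a saturated ring carbon. The same difference, cut one bond further out, reads propyl to methyl.

Compound 1 at 50% and compound 2 at 50% agree within the scatter although they differ in two places, which gives no ground for a sizeable step on the saturated chain. The step expected in this assay is no change at the digits printed from compound 2 to compound 3 (within the scatter), none beyond the scatter, in no firm direction. Compound 3 is accordingly expected to read 50% in this assay, with a range from 32% to 68%.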

Compound 3, a percentage reported as inhibition, at one concentration (the size of the read-out at that concentration, not a potency): 50%
Compound 3: middle estimate and measured number agree at the digits printed; the measured number falls inside the stated range.
By their numbers in this assay, from the lowest: compounds 1, 2 and 3 (each within the scatter of the next).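

In this assay, hydrogen in place of ethyl on a saturated chain carbon bound to a saturated ring carbon now has a measured size, no change at the digits printed from compound 2 to compound 3 (within the scatter), so this read-out does not separate the propyl and methyl forms of that chain. Hydrogen in place of cyclopropyl on an amide-type nitrogen also has a measured size, no change at the digits printed from compound 1 to compound 3 (within the scatter), so neither place shows a step beyond the scatter at the one concentration tested. No accompanying data bear on the reason for these two results.

A single-concentration percentage is not a potency, so these readings leave open whether potency differences among the three compounds would appear across a range of concentrations. Also open, going by these compounds, is whether a longer chain such as hexyl, or an amine or a carboxylic acid, on the saturated chain carbon, or a phenyl group on the amide-type nitrogen, would give a step beyond the scatter.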